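A few compounds are considered here, and "the series" means these few. Any claim that something is new, unique, unknown or untested is made for them only; others in the source may bear on it.

Series notes, values in an ADME assay on microsomes (Homo sapiens) for metabolic stability; a lower number here means that the compound disappears faster, a higher number that the compound lasts longer:

- compound 1 `Cc1noc(Cn2nc3ccc(-c4ccc(Oc5ccc(F)cc5)cc4)cn3c2=O)n1`: 2.12 h
- compound 2 `Cc1nc(Cn2nc3ccc(-c4ccc(OC(F)(F)F)cc4)cn3c2=O)no1`: 6.58 h
- compound 3 `Cc1nc(Cn2nc3ccc(-c4ccc(Oc5ccc(F)cc5)cc4)cn3c2=O)no1`: 3.45 h

Compound 3, at 3.45 h, falls between the values of compound 1 and compound 2, and within the scatter of each. The next compound to be measured is compound 4 `Cc1nc(Cn2nc3ccc(-c4ccc(Oc5ccc(Cl)cc5)cc4)cn3c2=O)no1`, with chloro in place of fluoro on an aromatic carbon, para to a large group, so that 4-fluorophenoxy becomes 4-chlorophenoxy: chloro in place of fluoro on an aromatic carbon.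

For the measured compounds named here, no measured step makes this exchange. The closest evidence replaces the same group as a whole: a 1.9-fold lower number from compound 2 to compound 3 (0.28 log units; within the scatter), with 4-fluorophenyl in place of trifluoromethyl on an oxygen. Even that wider replacement stayed within the scatter. The other step, a 1.6-fold higher number from compound 1 to compound 3 (0.21 log units; within the scatter), swaps the methyl-oxadiazole isomer on the chain and says little about the halogen. With only these steps to go on, no shift beyond the scatter is expected in this assay, and the direction is open. The expected step is a 1.1-fold lower number from compound 3 to compound 4 (0.03 log units; within the scatter). For compound 4 the estimated half-life is 3.2 h, with an expected range of 1.7 h to 6 h.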

Compound 4, half-life: 6.58 h
Compound 4: middle estimate off by 2.1-fold (0.31 log units), on the low side, and the stated range ends below it.
By their numbers in this assay, from the lowest: compounds 1, 3, 2 and 4 (each within the scatter of the next, the first and the last beyond it).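

Chloro in place of fluoro on an aromatic carbon, para to a large group, now has a direct reading in this assay: a 1.9-fold higher number from compound 3 to compound 4 (0.28 log units; within the scatter), so this single-atom exchange on the aryl ether stays within the scatter, though the step is as large as the wider replacement of the whole group in a 1.9-fold lower number from compound 2 to compound 3 (0.28 log units; within the scatter). Set against trifluoromethyl on the same oxygen, 4-chlorophenyl gives no change at the digits printed from compound 2 to compound 4 (within the scatter), so the two groups cannot be told apart here, and neither can the two halogens. No supporting data bear on why the half-life reads as it does for this exchange.

Only fluoro and chloro are shown at this place, so it remains open whether a methyl, a methoxy, a nitrile or an amine there would produce a step beyond the scatter. As far as these compounds go, it is also open whether chloro in place of fluoro reads the same with the 3-methyl-1,2,4-oxadiazol-5-yl group of compound 1 on the chain.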